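The source may report more compounds than this note shows. Statements on the series, on what has been measured and on what is new or still open speak of the compounds shown alone.

Measured in a toxicity assay on HeLa cells (Homo sapiens) for cytotoxicity, read by MTT assay, with a stated time of 24 h; a lower number here means a stronger inhibitor, a higher number a weaker inhibitor:
- compound 1 `Cc1ncc([N+](=O)[O-])n1CC(O)CSC(=S)N1CCOCC1`: 4520000 nM
- compound 2 `Cc1ncc([N+](=O)[O-])n1CC(O)CSC(=S)N1CCC(C)CC1`: 1820000 nM

Of these two compounds, compound 2 has the lower number, 1820000 nM, in this assay. The next compound to be tested is compound 3 `CCN(CC)C(=S)SCC(O)Cn1c([N+](=O)[O-])cnc1C`. It keeps the shared core but carries diethylamino in place of 4-methylpiperidin-1-yl on a thiocarbonyl carbon.

Among the compounds with values here, only one measured step bears on this change. That step, a 2.5-fold lower number from compound 1 to compound 2 (0.40 log units; beyond the scatter), was modest and was made at the same place, swapping one ring for another. Within the data shown here, no compound with an open-chain amino group has been measured, so the new group has no direct precedent, and a single step sets no trend. The modest size of that step nevertheless suggests only a small shift in this assay. A slightly higher number is expected, with no step beyond the scatter.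

The expected outcome is a 1.4-fold higher number from compound 2 to compound 3 (0.14 log units; within the scatter). For compound 3 the estimated value is 2500000 nM, with an expected range from 1000000 nM to 6000000 nM.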

Compound 3, half-maximal inhibitory concentration: 2460000 nM
Compound 3: middle estimate off by 1.0-fold (0.01 log units), on the high side; low and high end bracket the measured number.
By their numbers in this assay, from the lowest: compounds 2, 3 and 1 (each within the scatter of the next, the first and the last beyond it).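

Within the data shown here, with diethylamino on a thiocarbonyl carbon, the first open-chain group at this place, this assay gives a 1.4-fold higher number from compound 2 to compound 3 (0.13 log units; within the scatter) and a 1.8-fold lower number from compound 1 to compound 3 (0.26 log units; within the scatter). Neither step leaves the scatter, whereas the change between the two ring-bearing groups gave a 2.5-fold lower number from compound 1 to compound 2 (0.40 log units; beyond the scatter), so the group without a ring falls within the scatter of both, and among these three compounds a ring at this place is not needed for a number in this range. No available evidence accounts for these differences or for the lack of a clear separation among the three groups.

On these data alone, it remains open whether a longer chain, such as dibutylamino, would separate from these groups in this assay, or whether the numbers stay in the same range as the chains grow. As far as these compounds go, it is equally open how a charged or hydrogen-bonding substituent, such as a carboxylic acid on the piperidine ring or a free amine in a piperazine ring, would behave at this place on the shared core.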